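Triazole ester and acetonide analogues: cytotoxicity on melanoma cells

The source may report more compounds than this note shows. Statements on the series, on what has been measured and on what is new or still open speak of the compounds shown alone.

Measured compounds:
Compound 1 `CC1(C)OC[C@H](Cn2cc(-c3ccc([N+](=O)[O-])cc3)nn2)O1`: in a functional assay on B16 cells (Mus musculus) for cytotoxicity, read by MTT assay, with a stated time of 48 h (a higher number here means a weaker inhibitor, a lower number a stronger inhibitor), compound 1 gives > 100000 nM, which is a limit of the assay and not a number.
Compound 2 `CCOC(=O)Cn1cc(-c2ccc(OC)c(OC)c2OC)nn1`: in this assay compound 2 gives > 100000 nM, again a limit of the assay.
Compound 3 `CCOC(=O)Cn1cc(-c2ccc([N+](=O)[O-])cc2)nn1`: in this assay compound 3 gives > 100000 nM, also a limit of the assay.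

Going by the values given here, every value so far sits at the limit of > 100000 nM in this assay, at which 3 of the 3 values shown sit, so no compound in the set has yet given a readable number. Compound 3 and compound 1 differ in one place, (2,2-dimethyl-1,3-dioxolan-4-yl in place of ethoxycarbonyl on a saturated chain carbon bound to an aromatic nitrogen). The step that the two limits leave unreadable from compound 3 to compound 1 is therefore unreadable, both ends being limits. Compound 2 and compound 3 differ in another way; the difference between the two cores is not broken down here, and their two values show only that both are limits.

Compound 4 `COc1ccc(-c2cn(C[C@H]3COC(C)(C)O3)nn2)c(OC)c1OC` has not been measured. It stands to compound 2 as compound 1 stands to compound 3, through (2,2-dimethyl-1,3-dioxolan-4-yl in place of ethoxycarbonyl on a saturated chain carbon bound to an aromatic nitrogen). The place of the change is the same word for word in both pairs, so this is the same change made a second time.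

The expected step is a step that the limit leaves unreadable from compound 2 to compound 4, and this rests on a step that the two limits leave unreadable from compound 3 to compound 1, which showed no readable movement, and on compound 2 already sitting at a limit in this assay. Compound 4 is expected to give about 150000 nM in this assay. The estimated range for compound 4 runs from 40000 nM to 600000 nM, with most of the weight on another limit rather than a number.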

Compound 4, half-maximal inhibitory concentration: > 100000 nM
Compound 4 gave a limit, no number (the forecaster's own chance of this, stated with the estimate: 85%); the middle value is on the limit's open side.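

In this assay compound 4 gives > 100000 nM and this is a limit of the assay, not a number. The steps from compound 2 to compound 4 and from compound 3 to compound 1 therefore cannot be read: the limit of > 100000 nM in this assay, at which 4 of the 4 values shown sit.

The compounds shown leave open whether (2,2-dimethyl-1,3-dioxolan-4-yl)methyl and (ethoxycarbonyl)methyl differ at all in this assay, and whether either core can give a readable number there.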